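From compound 3 to compound 4: the amide nitrogen substituent

The source may report more compounds than this note shows. Statements on the series, on what has been measured and on what is new or still open speak of the compounds shown alone.

In a physicochemical assay for solubility, measured as kinetic solubility (on this read-out higher numbers stand for higher solubility and lower numbers for lower solubility), compound 3 `Cc1ccc(NC(=O)c2cc(Oc3cnc(C(=O)N(C)C)cn3)c3cc(C)oc3c2)nc1` reads 215000 nM. Compound 1 `Cc1cnc(NC(=O)c2cc(Oc3cnc(C(=O)N(C)C)cn3)c3cc(C)oc3c2)cn1` reads 176000 nM, which is within the scatter of compound 3. Compound 2 `Cc1cc2c(Oc3cnc(C(=O)N4CC(C)(C)C4)cn3)cc(C(=O)Nc3cnccn3)cc2o1` reads 78000 nM, a lower number than compound 3 and beyond the scatter from it.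

The next compound to be read is compound 4 `Cc1cc2c(Oc3cnc(C(=O)N(C)C)cn3)cc(C(=O)Nc3cnccn3)cc2o1`, which has pyrazin-2-yl in place of 5-methylpyridin-2-yl on an amide-type nitrogen.

Going by the values given here, one measured step bears directly on this change, at the same place on the structure: a 1.2-fold higher number from compound 1 to compound 3 (0.09 log units; within the scatter). That exchange of 5-methylpyrazin-2-yl for 5-methylpyridin-2-yl gave no change beyond the scatter in this assay. Among the compounds with values here, no measured step isolates the loss of the methyl group. Compound 2, at 78000 nM, carries pyrazin-2-yl at this place but differs elsewhere in the structure, so it serves only to keep the lower end of the range open.

The expected change is small, with a slightly lower number estimated: a 1.3-fold lower number from compound 3 to compound 4 (0.13 log units; within the scatter). For compound 4 the estimate is 160000 nM, with an expected range of 80000 nM to 300000 nM.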

Compound 4, solubility: 30000 nM
The estimate for compound 4 lay 5.3-fold (0.73 log units) above the measured number; the measured number lies below the stated range.
By their numbers in this assay, from the lowest: compound 4; then compound 2; then compounds 1 and 3 (each within the scatter of the next).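

In this assay the change at the amide-type nitrogen gives a 7.2-fold lower number from compound 3 to compound 4 (0.86 log units; beyond the scatter) and so moves the number far more than the exchange of 5-methylpyrazin-2-yl for 5-methylpyridin-2-yl, which gave a 1.2-fold higher number from compound 1 to compound 3 (0.09 log units; within the scatter) and stayed within the scatter. Removing the methyl group alone gives a 5.9-fold lower number from compound 1 to compound 4 (0.77 log units; beyond the scatter), so among compound 1, compound 3 and compound 4 the move beyond the scatter goes with the loss of the methyl group and not with the exchange of ring hetero atoms. With pyrazin-2-yl held constant, the group on the other carbonyl carbon also counts, since dimethylamino in place of 3,3-dimethylazetidin-1-yl gives a 2.6-fold lower number from compound 2 to compound 4 (0.41 log units; beyond the scatter) and the low number of compound 4 is therefore tied to more than one place on the structure.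

The data shown offer no measured reason for any of these steps. Still open, on these data alone, are whether unsubstituted pyridin-2-yl follows pyrazin-2-yl, whether an ethyl or methoxy group can stand in for the methyl group, and whether the methyl step keeps its size with 3,3-dimethylazetidin-1-yl on the carbonyl carbon.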